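Fluorinated Alcohol in Place of an Oxime Side Chain

This account rests on a few compounds, and the source may have more. Where it says the series, first, only, none or still open, it means among the compounds named here.

Compound 1 `O=C(CCCCCCNC(=O)C(O)(O)C(F)(F)F)Nc1nc2ccc(Br)cc2s1` gives 10300 nM in a functional assay on HCT-116 cells (Homo sapiens) for inhibition, read by colorimetric assay, with a stated time of 3 days; a higher number here means a weaker inhibitor, a lower number a stronger inhibitor. Compound 2 `C/C(=N\O)C(=O)NCCCCCC(=O)Nc1ccccc1` reaches only a limit of this assay, reported as > 100000 nM, so no number is known for it. Compound 2 sits at the limit of > 100000 nM in this assay, at which 1 of the 2 values shown sits. Compound 3 `O=C(CCCCCCC(O)C(F)(F)F)Nc1ccccc1` differs from compound 2 in one place: a group of 7 heavy atoms (3 carbon, 1 oxygen, 3 fluorine; no ring) in place of a group of 7 heavy atoms (3 carbon, 2 nitrogen, 2 oxygen; no ring), on a saturated chain carbon, five bonds along the chain from a carbonyl carbon. Since compound 2 shows only a limit, the step in this assay cannot be sized from the data; a modest shift toward a stronger inhibitor is expected, though it may still end at the limit. Compound 3 is expected near 50000 nM, within 15000 nM to 200000 nM. This expected step is an at least 2.0-fold lower number from compound 2 to compound 3 (0.30 log units; that floor lies within the scatter).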

Compound 3, half-maximal inhibitory concentration: > 40000 nM
Compound 3: no number, only a limit; the forecaster's own chance of this, stated with the estimate: 50%; the middle value does not contradict the limit.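

Among the compounds shown here, compound 2 and compound 3 each reach only a limit of this assay, so no step between them can be read. As far as these compounds go, how strongly either compound actually inhibits, and whether the swapped side chain changes that, stays open.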